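Two Triazine Analogues at the Limit, a Third Predicted

The source may report more compounds than this note shows. Statements on the series, on what has been measured and on what is new or still open speak of the compounds shown alone.

Compound 1: `N#Cc1ccc(Nc2nc(Oc3ccnc4ccccc34)nc(N3CCN(c4ccccc4Cl)CC3)n2)cc1C(F)(F)F` — > 100000 nM
Compound 2: `CN1CCN(c2nc(Nc3ccc(C#N)c(C(F)(F)F)c3)nc(Oc3ccnc4ccccc34)n2)CC1` — > 100000 nM

The study measures cytotoxicity in a functional assay on DU-145 cells (Homo sapiens) for cytotoxicity, read by sulforhodamine B assay, with a stated time of 48 h; a higher number here means that more compound is tolerated, a lower number that less compound is tolerated. In this assay compound 1 reaches only the limit of the assay, > 100000 nM, not a number. Compound 2 likewise sits at the limit, > 100000 nM. Among the compounds with values here, the one measured step, a step that the two limits leave unreadable from compound 1 to compound 2, therefore cannot be read, and the limit of > 100000 nM in this assay, at which 2 of the 2 values shown sit, is the only evidence the two values give: both compounds tolerate more compound than the assay can report.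

Compound 3, `N#Cc1ccc(Nc2nc(Oc3ccnc4ccccc34)nc(N3CCN(c4cccc(C(F)(F)F)c4)CC3)n2)cc1C(F)(F)F`, differs from compound 1 by 3-(trifluoromethyl)phenyl in place of 2-chlorophenyl on an amine nitrogen in a ring. Within the data shown here, no measured step bears on this change, and compound 1 itself stands only at a limit, so nothing in the numbers points in either direction. The expectation for compound 3 is therefore that it too lies at or beyond the limit, with a step that the limit leaves unreadable from compound 1 to compound 3 expected to be no step beyond the scatter. Compound 3 is estimated at 150000 nM, within 50000 nM to 500000 nM.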

Compound 3, concentration lethal to 50% of the cells: > 100000 nM
Compound 3: no number, only a limit (the forecaster's own chance of this, stated with the estimate: 85%); the middle value is on the limit's open side.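

Within the data shown here, compound 3 gives only a limit in this assay, so no step among compound 1, compound 2 and compound 3 can be read: the limit of > 100000 nM in this assay, at which 3 of the 3 values shown sit.

The compounds shown leave open how far each lies beyond that limit, and whether the group on the amine nitrogen in the ring matters.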